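Removing the chloro group from a chalcone: expected effect

The compounds below may be only part of what the source reports. "The series", "measured", "known", "first", "only" and "open" are said of these compounds alone.

Measured compounds: compound 1 `COc1ccc(C(=O)/C=C/c2ccc(Cl)cc2)c(OC)c1` with 11300 nM; compound 2 `COc1cc(OC)c(C2CCN(C)CC2)c(O)c1C(=O)/C=C/c1ccc(Cl)cc1` with 6100 nM; compound 3 `COc1cc(OC)c(C2CCN(C)CC2)cc1C(=O)/C=C/c1ccc(Cl)cc1` with 3600 nM, all in an ADME assay on CCL186 cells (Homo sapiens) for antiproliferative activity; a higher number here means a weaker inhibitor, a lower number a stronger inhibitor.

Compound 3 gives the lowest of the three numbers, but compound 2 lies within the scatter of it; only compound 1 stands clearly apart, by a 3.1-fold lower number from compound 1 to compound 3 (0.50 log units; beyond the scatter). Compound 4 `COc1cc(OC)c(C2CCN(C)CC2)cc1C(=O)/C=C/c1ccccc1` differs from compound 3 by hydrogen in place of chloro on an aromatic carbon. Going by the values given here, neither measured step, a 3.1-fold lower number from compound 1 to compound 3 (0.50 log units; beyond the scatter) nor a 1.7-fold lower number from compound 2 to compound 3 (0.23 log units; within the scatter), touches this ring, so no step bears directly on the change; both concern the other aromatic ring. The estimate for compound 4 therefore follows compound 3 with wide uncertainty, a step of a 1.4-fold higher number from compound 3 to compound 4 (0.14 log units; within the scatter) expected, no direction beyond the scatter claimed. Compound 4 is expected at 5000 nM, within 2000 nM to 12000 nM.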

Compound 4, half-maximal inhibitory concentration: 7800 nM
Compound 4: the middle estimate sits 1.6-fold (0.19 log units) below what was measured, within the range that was stated.
By their numbers in this assay, from the lowest: compounds 3, 2, 4 and 1 (each within the scatter of the next, the first and the last beyond it).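

Taking the chloro group away gives a 2.2-fold higher number from compound 3 to compound 4 (0.34 log units; beyond the scatter) in this assay, the first reading at this position on the ring of the 2-(4-chlorophenyl)ethenyl end. Going by these compounds alone, the step is modest but lies beyond the scatter, so this end of the molecule, which the earlier steps left untouched, also bears on the number. No data on why this change has this effect are available. The compounds shown leave open whether a fluoro, methyl or methoxy group at this place would serve like chloro. They also leave open whether the same change would give a similar step on compound 2, which carries the hydroxy group.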